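Ethoxy versus methoxy in a sulfonyl acylguanidine series

A few compounds are considered here, and "the series" means these few. Any claim that something is new, unique, unknown or untested is made for them only; others in the source may bear on it.

Compound 1, with the structure `CSc1cc(C)c(C(=O)N=C(N)N)cc1S(C)(=O)=O`, is measured in a functional assay for inhibition of sodium/hydrogen exchanger (Oryctolagus cuniculus) (on this read-out higher numbers stand for weaker inhibition and lower numbers for stronger inhibition), and gives 6 nM. Compound 2, `CCSc1cc(C)c(C(=O)N=C(N)N)cc1S(C)(=O)=O`, gives 5.9 nM in this assay, and the step of a 1.0-fold lower number from compound 1 to compound 2 (0.01 log units; within the scatter) is tied to the change (methyl in place of hydrogen on a saturated chain carbon bound to a sulfur). Compound 3, `COc1cc(C)c(C(=O)N=C(N)N)cc1S(C)(=O)=O`, gives 16 nM in this assay; the steps of a 2.7-fold higher number from compound 1 to compound 3 (0.43 log units; beyond the scatter) and a 2.7-fold higher number from compound 2 to compound 3 (0.43 log units; beyond the scatter) both point the same way. Compound 4, `CCOc1cc(C)c(C(=O)N=C(N)N)cc1S(C)(=O)=O`, is not yet measured. It differs from compound 3 by methyl in place of hydrogen on a saturated chain carbon bound to an oxygen on an aromatic ring. Within the data shown here, this is the same kind of change as the one from compound 1 to compound 2, but the surroundings differ: there the carbon is bound to a sulfur, here it is bound to an oxygen on an aromatic ring. The two cores differ by methoxy in place of methylsulfanyl on an aromatic carbon. Resting on a 1.0-fold lower number from compound 1 to compound 2 (0.01 log units; within the scatter), which stayed within the scatter, the step for compound 4 is expected to be small, no change at the digits printed from compound 3 to compound 4 (within the scatter). Compound 4 is therefore estimated at 16 nM in this assay, with a range from 8 nM to 32 nM.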

Compound 4, half-maximal inhibitory concentration: 19 nM
Compound 4: middle estimate off by 1.2-fold (0.07 log units), on the low side; measured number inside the range.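

For methoxy to ethoxy the step in this assay is a 1.2-fold higher number from compound 3 to compound 4 (0.07 log units; within the scatter), and it matches the step for the same change on the sulfur-linked chain: the same change on two cores in this assay, a 1.0-fold lower number (0.01 log units; within the scatter) from compound 1 to compound 2 and a 1.2-fold higher number (0.07 log units; within the scatter) from compound 3 to compound 4, 1.2-fold (0.08 log units) apart, within the scatter of two such steps. Compound 4 also keeps the gap that separates compound 3 from the sulfur-linked compounds, the steps being a 3.2-fold higher number from compound 2 to compound 4 (0.51 log units; beyond the scatter) and a 3.2-fold higher number from compound 1 to compound 4 (0.50 log units; beyond the scatter), both beyond the scatter. Among these compounds, this shows only that a step too small to read stayed too small to read on both cores; with a single pair on each core, it does not show that a larger change would carry over in the same way, or that this one would hold on any other core.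

The compounds shown leave open whether a longer chain, such as propyl or butyl, would stay as flat on either core. They also leave open what a chain ending in an amine or a carboxylic acid would do there.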